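The source may hold more compounds than are shown below. What is called first, only, known or untested is meant among the compounds shown, and "the series" means these compounds.

Three compounds have been measured in an in vivo functional assay on the whole organism for inhibition of 3-hydroxy-3-methylglutaryl-coenzyme A reductase (Rattus norvegicus), at a dose of 2 mg/kg by the oral route; a higher number here means a stronger effect of the compound at the dose given, a lower number a weaker effect:

Compound 1 `Cc1nn(C(C)(C)C)c2nc(C3CC3)c(/C=C/[C@@H](O)C[C@@H](O)CC(=O)O)c(-c3ccc(F)cc3)c12` gives 72.2%
Compound 2 `Cc1nn(C(C)(C)C)c2nc(C(C)C)c(/C=C/[C@@H](O)C[C@@H](O)CC(=O)O)c(-c3ccc(F)cc3)c12` gives 86%
Compound 3 `CCc1c(C)sc2nc(C(C)C)c(/C=C/[C@@H](O)C[C@@H](O)CC(=O)O)c(-c3ccc(F)cc3)c12` gives 20.8%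

Compound 2 stands highest of these three numbers. Going by the values given here, its nearest neighbour is compound 1, and the single measured step joins them: a number 13.8 percentage points higher from compound 1 to compound 2 (beyond the scatter). Among the compounds with values here, compound 3 lies furthest away; no single-point step connects it to compound 2, so the two values show only that compound 3 sits far below compound 2 in this assay.

Compound 4 `COc1ccc(-n2nc(C)c3c(-c4ccc(F)cc4)c(/C=C/[C@@H](O)C[C@@H](O)CC(=O)O)c(C(C)C)nc32)cc1` has not yet been measured. Compared with compound 2 it carries 4-methoxyphenyl in place of tert-butyl on an aromatic nitrogen. Within the data shown here, the one measured step concerns a different position, the isopropyl in place of cyclopropyl on an aromatic carbon, and it is modest in size. Among the measured compounds shown here, no measured pair changes the group on the aromatic nitrogen, so there is no basis for expecting a shift in a particular direction; the step of a number 16 percentage points lower from compound 2 to compound 4 (beyond the scatter) is therefore expected to be small relative to the uncertainty, with a wide range. Compound 4 is estimated to give about 70% in this assay, between 40% and 92%.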

Compound 4, a percentage reported as inhibition, in the whole organism at one dose (the size of the read-out at that dose, not a potency): 48.7%
For compound 4 the middle estimate is 21.3 percentage points above the measured one, within the range that was stated.
By their numbers in this assay, from the lowest: compound 3; then compound 4; then compound 1; then compound 2.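

In this assay, the group on the aromatic nitrogen clearly matters: exchanging tert-butyl for 4-methoxyphenyl gives a number 37.3 percentage points lower from compound 2 to compound 4 (beyond the scatter) and this step is larger than the earlier one on the aromatic carbon, a number 13.8 percentage points higher from compound 1 to compound 2 (beyond the scatter). The exchange alters several things at once, replacing a group of 4 heavy atoms with no ring by one of 8 heavy atoms with a six-membered aromatic ring and a hydrogen-bond acceptor, so this single pair cannot show which of these differences goes with the lower number. No measurement shown here accounts for the drop, and the read-out reflects the effect at one oral dose in the whole animal rather than a potency.

The compounds shown leave open whether plain phenyl on the same nitrogen would give a number near that of the tert-butyl compound or near that of the 4-methoxyphenyl compound, which would help separate the ring from its methoxy group. They also leave open how smaller groups on this nitrogen, such as methyl or ethyl, would behave, and whether the isopropyl and cyclopropyl step would keep its size with an aromatic ring there.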